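Aryl swap on the ring nitrogen: chloro to fluoro

A few compounds are considered here, and "the series" means these few. Any claim that something is new, unique, unknown or untested is made for them only; others in the source may bear on it.

Compound 1 `CC#CC(CC(=O)O)c1ccc(OCc2ccc(C(=O)N3CCN(c4ccncc4)CC3)s2)cc1` and compound 2 `CC#CC(CC(=O)O)c1ccc(OCc2ccc(C(=O)N3CCN(c4ccc(Cl)cc4)CC3)s2)cc1` were measured in a functional assay on HEK293 cells for agonist activity at Free fatty acid receptor 1 (Homo sapiens), read by fluorescence and calcium flux; on this read-out higher numbers stand for an effect only at larger amounts of compound and lower numbers for an effect already at smaller amounts. In this assay compound 1 reaches only the limit > 5000 nM. Among the measured compounds shown here, compound 2 gives 133 nM, the only number reported here. For the measured compounds named here, the step of an at least 37-fold lower number from compound 1 to compound 2 (1.57 log units; beyond the scatter) is the sole measured comparison and concerns the same ring nitrogen that compound 3 `CC#CC(CC(=O)O)c1ccc(OCc2ccc(C(=O)N3CCN(c4cccc(F)c4)CC3)s2)cc1` alters: 3-fluorophenyl in place of 4-chlorophenyl on an amine nitrogen in a ring. Because that step ran from a limit of > 5000 nM in this assay, at which 1 of the 2 values shown sits, to a number, it shows how much this position can matter but gives no direct measure of chloro against fluoro. Compound 3 is therefore expected to change modestly, a 2.3-fold higher number from compound 2 to compound 3 (0.35 log units; beyond the scatter), with an estimated 300 nM between 100 nM and 900 nM.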

Compound 3, half-maximal effective concentration: 97 nM
Estimate against measurement, compound 3: 3.1-fold (0.49 log units) above, outside the stated range (below it).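

In this assay, the swap gives a 1.4-fold lower number from compound 2 to compound 3 (0.14 log units; within the scatter), so 3-fluorophenyl and 4-chlorophenyl cannot be told apart on this amine nitrogen in a ring. A second aryl group of carbon only now also stands well clear of the pyridin-4-yl of compound 1, with an at least 51-fold lower number from compound 1 to compound 3 (1.71 log units; beyond the scatter). That step starts from a limit, so its size is only a bound: the limit of > 5000 nM in this assay, at which 1 of the 3 values shown sits.

The swap changes the halogen and its place together, and the compounds shown do not separate the two. On these data alone, how a 3-chlorophenyl, a 4-fluorophenyl or a plain phenyl would read here remains open.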